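Swapping the aryl group on the pyridazinone nitrogen

The source may report more compounds than this note shows. Statements on the series, on what has been measured and on what is new or still open speak of the compounds shown alone.

Measured compounds:
compound 1, `Cc1cc(=O)n(-c2ccc(Br)cc2F)nc1C(=O)Nc1ccc(Oc2ncnc3ccsc23)c(F)c1`, 2980 nM
compound 2, `Cc1cc(=O)n(-c2ccccc2OC(F)(F)F)nc1C(=O)Nc1ccc(Oc2ncnc3ccsc23)c(F)c1`, 5720 nM
compound 3, `Cc1ccc(-n2nc(C(=O)Nc3ccc(Oc4ncnc5ccsc45)c(F)c3)c(C)cc2=O)cc1`, 5890 nM

All three compounds were tested in a functional assay on A549 cells (Homo sapiens) for cytotoxicity, read by MTT assay, with a stated time of 72 h; a lower number here means a stronger inhibitor, a higher number a weaker inhibitor. Compound 3 gives 5890 nM, the highest of the three numbers, though its nearest neighbour, compound 2, lies a 1.0-fold higher number from compound 2 to compound 3 (0.01 log units; within the scatter) and the furthest, compound 1, lies a 2.0-fold higher number from compound 1 to compound 3 (0.30 log units; within the scatter), so none of the three is separated from another beyond the scatter.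

Compound 4, `Cc1cc(=O)n(-c2ccc(F)c(F)c2)nc1C(=O)Nc1ccc(Oc2ncnc3ccsc23)c(F)c1`, has not yet been measured. It differs from compound 3 in one place: 3,4-difluorophenyl in place of 4-methylphenyl on an aromatic nitrogen. Within the data shown here, the steps that bear on this are those that swap the aryl group on the same aromatic nitrogen, a 1.9-fold higher number from compound 1 to compound 2 (0.28 log units; within the scatter) and a 2.0-fold higher number from compound 1 to compound 3 (0.30 log units; within the scatter), both within the scatter. On that basis compound 4 is expected to show no step beyond the scatter in this assay, with the estimated change being a 1.3-fold lower number from compound 3 to compound 4 (0.12 log units; within the scatter). Compound 4 is therefore estimated at 4500 nM, with a range from 1500 nM to 13000 nM.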

Compound 4, half-maximal inhibitory concentration: 4590 nM
Compound 4: the middle estimate sits 1.0-fold (0.01 log units) below what was measured; low and high end bracket the measured number.
By their numbers in this assay, from the lowest: compounds 1, 4, 2 and 3 (each within the scatter of the next).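

With 3,4-difluorophenyl as a fourth aryl group on this aromatic nitrogen, this assay again shows no step beyond the scatter, with a 1.3-fold lower number from compound 3 to compound 4 (0.11 log units; within the scatter) and a 1.2-fold lower number from compound 2 to compound 4 (0.10 log units; within the scatter) and a 1.5-fold higher number from compound 1 to compound 4 (0.19 log units; within the scatter). The aryl group that enters here carries only fluorine on its ring, yet the step from 4-methylphenyl stays within the scatter, and so do the steps from the two other aryl groups. No measurement offered here accounts for this lack of separation.

All four groups at this position are substituted phenyl rings, so the compounds shown leave open whether a saturated cyclohexyl ring or a short chain ending in an amine or a carboxylic acid would move the number beyond the scatter. They also do not tell whether these aryl groups would stay unseparated in another assay.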